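This account rests on a few compounds, and the source may have more. Where it says the series, first, only, none or still open, it means among the compounds named here.

Compound 1 `CC(C)=CC[C@@H](OC(=O)c1ccco1)C1=CC(=O)c2c(O)ccc(O)c2C1=O` gives 80300 nM in a functional assay on HeLa cells (Homo sapiens) for cytotoxicity, read by MTT assay; a higher number here means a weaker inhibitor, a lower number a stronger inhibitor.
Compound 2 `CC(=O)OCCC(=O)O[C@H](CC=C(C)C)C1=CC(=O)c2c(O)ccc(O)c2C1=O` gives 17300 nM in this assay.

Of the two measured compounds, compound 1 stands with the higher number. Among the measured compounds shown here, the single measured step, a 4.6-fold lower number from compound 1 to compound 2 (0.67 log units; beyond the scatter), replaced the same furan-2-yl group on the carbonyl carbon with an open chain. Compound 3 `CCC(C)(O)CC(=O)O[C@H](CC=C(C)C)C1=CC(=O)c2c(O)ccc(O)c2C1=O` differs from compound 1 in the same position: 2-hydroxy-2-methylbutyl in place of furan-2-yl on a carbonyl carbon. As the entering group is again an open chain bearing an oxygen, a step of similar size in the same direction is expected, so compound 3 is estimated at 25000 nM, within a range from 8000 nM to 70000 nM, which means an expected 3.2-fold lower number from compound 1 to compound 3 (0.51 log units; beyond the scatter).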

Compound 3, half-maximal inhibitory concentration: 25200 nM
For compound 3 the middle estimate is 1.0-fold (0.00 log units) below the measured one; low and high end bracket the measured number.
By their numbers in this assay, from the lowest: compounds 2 and 3 (each within the scatter of the next); then compound 1.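

Replacing furan-2-yl with 2-hydroxy-2-methylbutyl on the carbonyl carbon gives a 3.2-fold lower number from compound 1 to compound 3 (0.50 log units; beyond the scatter) in this assay, so a second open chain moves the same way as the first. The two open chains are not told apart, with a 1.5-fold higher number from compound 2 to compound 3 (0.16 log units; within the scatter) within the scatter. No supporting data bear on why either open chain differs from furan-2-yl.

As far as these compounds go, whether a plain butyl chain, or a chain carrying an amine or a carboxylic acid, would follow the same step remains open. So does whether a phenyl ring would stand with furan-2-yl.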